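Benzyl ring substitution in a trimethoxyphenyl amide series

A few compounds are considered here, and "the series" means these few. Any claim that something is new, unique, unknown or untested is made for them only; others in the source may bear on it.

Working notes on the series. Compound 1 `COc1ccc(CN(C(=O)CSc2nc3ccccc3s2)c2cc(OC)c(OC)c(OC)c2)cc1C` and compound 2 `COc1ccc(CN(C(=O)CSc2nc3ccccc3s2)c2cc(OC)c(OC)c(OC)c2)cc1` share one core and differ only in the benzyl ring. In a functional assay on PC-3 cells (Homo sapiens) for antiproliferative activity, read by MTT assay, with a stated time of 48 h (a lower number here means a stronger inhibitor, a higher number a weaker inhibitor), compound 1 gives 34300 nM, while compound 2 gives 8460 nM. Among the measured compounds shown here, the one measured step, a 4.1-fold lower number from compound 1 to compound 2 (0.61 log units; beyond the scatter), came from a hydrogen in place of methyl on an aromatic carbon. Compound 2 therefore stands at the lowest of the two numbers, with compound 1 the nearest neighbour at a higher number beyond the scatter.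

Compound 3 `COc1cc(CN(C(=O)CSc2nc3ccccc3s2)c2cc(OC)c(OC)c(OC)c2)cc(OC)c1OC` is not yet measured. It differs from compound 2 by 3,4,5-trimethoxyphenyl in place of 4-methoxyphenyl on a saturated chain carbon bound to an amide-type nitrogen. For the measured compounds named here, no measured step tests this change directly. Going by the values given here, the only step in hand, a 4.1-fold lower number from compound 1 to compound 2 (0.61 log units; beyond the scatter), concerns the same ring and shows that removing a group there lowered the number; by that lone hint, adding two methoxy groups to this ring would be expected to raise the number, but the entering group is different and the guide is weak, so a modest upward step at the edge of the scatter is expected in this assay.

Compound 3 is expected to give 14000 nM, within 5000 nM to 45000 nM. The expected step is a 1.7-fold higher number from compound 2 to compound 3 (0.22 log units; within the scatter).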

Compound 3, half-maximal inhibitory concentration: > 80000 nM
Compound 3: a limit, no number; the forecaster's own chance of this, stated with the estimate: 10%; middle value at least 5.7-fold (0.75 log units) away from the limit.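

For compound 3, the reading in this assay is a limit and not a number: the limit of > 80000 nM in this assay, at which 1 of the 3 values shown sits. At this place, on a saturated chain carbon bound to an amide-type nitrogen, 3,4,5-trimethoxyphenyl in place of 4-methoxyphenyl gives an at least 9.4-fold higher number from compound 2 to compound 3 (0.97 log units; beyond the scatter), which shows that the series responds to added methoxy groups on this ring and not only to the methyl group compared so far. The same entering group in place of 4-methoxy-3-methylphenyl gives an at least 2.3-fold higher number from compound 1 to compound 3 (0.36 log units; beyond the scatter), so among the three groups shown, 4-methoxyphenyl gives the lowest number, and neither substituted alternative matches it, with no compound here going against that order.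

The compounds shown leave open how far compound 3 lies past its limit and which feature of the 3,4,5-trimethoxyphenyl group accounts for the step, since the two added methoxy groups enter together and cannot be separated here. They also leave open whether an unsubstituted phenyl, a 4-hydroxyphenyl or a phenyl carrying an amine or a carboxylic acid on this carbon would fall below compound 2.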